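This account rests on a few compounds, and the source may have more. Where it says the series, first, only, none or still open, it means among the compounds named here.

The measured compounds:
Compound 1 `COc1nc(NC(=O)C(=O)c2cn(C(C)C)c3ccccc23)ns1`: in a functional assay on FaDu cells (Homo sapiens) for cytotoxicity, read by MTT assay, with a stated time of 72 h (on this read-out lower numbers stand for higher toxicity in this test and higher numbers for lower toxicity in this test), compound 1 gives > 10000 nM, which is a limit of the test and not a number.
Compound 2 `CC(C)n1cc(C(=O)C(=O)Nc2ccc(OC(F)(F)F)cc2)c2ccccc21`: in this assay compound 2 gives 8930 nM.
Compound 3 `COc1ccc(NC(=O)C(=O)c2cn(CC(C)(C)OC)c3ccccc23)cn1`: in this assay compound 3 gives > 10000 nM, again a limit of the test rather than a number.

Compound 3 therefore stands at the limit of the test, with only a bound known; compound 1 sits at the same limit, so two of the three values shown are limits (the limit of > 10000 nM in this assay, at which 2 of the 3 values shown sit). Only compound 2 gives a number, and that number lies near the limit. Among the measured compounds shown here, no two of the measured compounds differ in a single place, so no step between them can be read off.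

Compound 4 `COc1ccc(NC(=O)C(=O)c2cn(C3CCCC3)c3ccccc23)cn1` differs from compound 3 in one place: cyclopentyl in place of 2-methoxy-2-methylpropyl on an aromatic nitrogen. For the measured compounds named here, none of the measured compounds carries the cyclopentyl group, so the measured values say nothing about this change. With compound 3 at the limit, the expected step from compound 3 to compound 4 in this assay is an at least 1.1-fold lower number from compound 3 to compound 4 (0.04 log units; that floor lies within the scatter), understood as no change beyond the scatter, with the direction left open by the limit. Compound 4 is thus expected to give about 9000 nM in this assay, within 3000 nM to 30000 nM, with a real chance that only a limit is reported.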

Compound 4, concentration lethal to 50% of the cells: 370 nM
The estimate for compound 4 lay 24-fold (1.39 log units) above the measured number, and the stated range ends above it.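

In this assay, the group on the aromatic nitrogen proves able to decide the read-out: cyclopentyl in place of 2-methoxy-2-methylpropyl gives an at least 27-fold lower number from compound 3 to compound 4 (1.43 log units; beyond the scatter). This is the first step between compounds shown that differ in one place, and it shows that this position alone can move the number far beyond the scatter while the rest of the molecule stays the same. Compound 3 stands at a limit of the test, so the step has only a lower bound and its full size stays unknown: the limit of > 10000 nM in this assay, at which 2 of the 4 values shown sit.

The compounds shown do not separate the arrival of the five-membered carbon ring from the departure of the oxygen-bearing, ring-free 2-methoxy-2-methylpropyl chain, as both happen in this one change. They also leave open how a cyclobutyl or cyclohexyl ring, or a chain ending in an amine, would read at this position on the same core, and whether the gain from cyclopentyl would carry over to the other amide groups seen in compound 1 and compound 2.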